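This account rests on a few compounds, and the source may have more. Where it says the series, first, only, none or still open, it means among the compounds named here.

Measured compounds: compound 1 `C[C@H](NC(=O)Nc1ccccc1Cl)c1ccccc1` with 104%; compound 2 `C[C@@H](NC(=O)Nc1cccc(Cl)c1)c1ccccc1` with 91%; compound 3 `C[C@H](NC(=O)Nc1c(Cl)cccc1Cl)c1ccccc1` with 99%.

In an ADME assay on the whole organism with Oryza sativa as the target, tested at 1 uM (on this read-out lower numbers stand for a stronger effect and higher numbers for a weaker effect at the one concentration tested), compound 1 gives 104%, compound 2 gives 91% and compound 3 gives 99%. The difference between the cores of compound 1 and compound 2 is not broken down here. Compound 3 arises from compound 1 by chloro in place of hydrogen on an aromatic carbon. This step gave a number 5 percentage points lower from compound 1 to compound 3 (within the scatter). Compound 4 `C[C@@H](NC(=O)Nc1cc(Cl)cc(Cl)c1)c1ccccc1` has not yet been measured in this assay; it arises from compound 2 by chloro in place of hydrogen on an aromatic carbon, the same kind of change, though in compound 3 the entering chloro sits ortho to a large group and in compound 4 meta to a large group. Because the earlier step of a number 5 percentage points lower from compound 1 to compound 3 (within the scatter) stayed within the scatter, compound 4 is expected to show a step of a number 3 percentage points lower from compound 2 to compound 4 (within the scatter). For compound 4 the estimated value is 88%.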

Compound 4, a percentage reported as activity, at one concentration (the size of the read-out at that concentration, not a potency): 99%
Compound 4: the middle estimate sits 11 percentage points below what was measured, within the range that was stated.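

In this assay, chloro in place of hydrogen on an aromatic carbon gave a number 8 percentage points higher from compound 2 to compound 4 (within the scatter). Set beside the earlier step, the change reads alike on the two cores: the same change on two cores in this assay, a number 5 percentage points lower (within the scatter) from compound 1 to compound 3 and a number 8 percentage points higher (within the scatter) from compound 2 to compound 4, 13 percentage points apart, within the scatter of two such steps. This gives no sign that the core alters the outcome of the change, but since neither step leaves the scatter, it shows no measurable effect of the chloro on either core, and two pairs do not establish a rule for the series.

The compounds shown carry only chloro on the aromatic ring, which leaves open whether a nitrile, a methoxy group or an amine there would move the read-out beyond the scatter. On these data alone, whether a longer chain in place of the methyl group would do so also remains open.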